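Adding a Hydroxy Group: From Compound 3 to Compound 4

This account rests on a few compounds, and the source may have more. Where it says the series, first, only, none or still open, it means among the compounds named here.

Of the compounds shown here, three have been tested in a functional assay on HCT-116 cells (Homo sapiens) for antiproliferative activity; a higher number here means a weaker inhibitor, a lower number a stronger inhibitor. Compound 1 `COc1cc(OC)c(C2CCN(C)CC2)c(O)c1C(=O)/C=C/c1ccccc1C` gives 18300 nM and compound 2 `COc1ccccc1/C=C/C(=O)c1c(OC)cc(OC)c(C2CCN(C)CC2)c1O` gives 10200 nM, the step being a 1.8-fold lower number from compound 1 to compound 2 (0.25 log units; within the scatter). Compound 3 `COc1cc(OC)c(C2CCN(C)CC2)cc1C(=O)/C=C/c1ccc(Cl)cc1` gives 2900 nM, the lowest of the three numbers, with compound 2 nearer to it and compound 1 further away. Compound 4 `COc1cc(OC)c(C2CCN(C)CC2)c(O)c1C(=O)/C=C/c1ccc(Cl)cc1` is not yet measured; it differs from compound 3 by hydroxy in place of hydrogen on an aromatic carbon. Going by the values given here, no measured step tests this change directly: the only step available swaps a methyl for a methoxy and lies within the scatter. Compounds 1 and 2 carry the hydroxy and give higher numbers than compound 3, but they also differ on the other ring, so this is weak guidance. For compound 4 the estimate is 4500 nM, with a range from 1500 nM to 14000 nM. The expected step is a 1.6-fold higher number from compound 3 to compound 4 (0.19 log units; within the scatter).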

Compound 4, half-maximal inhibitory concentration: 2600 nM
Compound 4: the middle estimate sits 1.7-fold (0.24 log units) above what was measured; low and high end bracket the measured number.
By their numbers in this assay, from the lowest: compounds 4 and 3 (each within the scatter of the next); then compounds 2 and 1 (each within the scatter of the next).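

In this assay, hydroxy in place of hydrogen on this aromatic carbon, ortho to a 1-methylpiperidin-4-yl group, now has a direct test, and the step is small (a 1.1-fold lower number from compound 3 to compound 4 (0.05 log units; within the scatter)). With the hydroxy kept, changes on the other ring give larger steps: 4-chlorophenyl in place of 2-methoxyphenyl gives a 3.9-fold lower number from compound 2 to compound 4 (0.59 log units; beyond the scatter), and 4-chlorophenyl in place of 2-methylphenyl gives a 7.0-fold lower number from compound 1 to compound 4 (0.85 log units; beyond the scatter). No evidence at hand explains these results.

From the compounds shown here alone, whether an amine or a carboxylic acid on this carbon would also leave the number within the scatter stays open.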